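Amide aryl exchange on the shared core of compound 1

The source may hold more compounds than are shown below. What is called first, only, known or untested is meant among the compounds shown, and "the series" means these compounds.

Compound 1 has the structure `O=C(Nc1ccc(Cl)c(-c2nnc3c(Cl)cccn23)c1)c1cccnc1`. In a functional assay on A549 cells (Homo sapiens) for antiproliferative activity, read by MTT assay, with a stated time of 72 h (a lower number here means a stronger inhibitor, a higher number a weaker inhibitor), compound 1 reaches only the limit of the assay, > 100000 nM. Compound 2, `CS(=O)(=O)c1ccc(C(=O)Nc2ccc(Cl)c(-c3nnc4c(Cl)cccn34)c2)cc1`, carries 4-(methylsulfonyl)phenyl in place of pyridin-3-yl on the carbonyl carbon. In this assay compound 2 likewise stops at the limit, > 100000 nM. Between them lies a step that the two limits leave unreadable from compound 1 to compound 2. Where compound 2 stands on the numbers is thus a limit only, and the one further value shown is a limit as well; the limit of > 100000 nM in this assay, at which 2 of the 2 values shown sit, sums up all that the pair yields.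

Compound 3, `Cc1cc(Cl)ccc1C(=O)Nc1ccc(Cl)c(-c2nnc3c(Cl)cccn23)c1`, differs from compound 2 by 4-chloro-2-methylphenyl in place of 4-(methylsulfonyl)phenyl on a carbonyl carbon. Within the data shown here, no measured step reads on this change: the only step available, a step that the two limits leave unreadable from compound 1 to compound 2, sits between two limits and gives neither size nor direction for this assay. Because compound 1 and compound 2 both sit at the limit of > 100000 nM in this assay, at which 2 of the 2 values shown sit, compound 3 is expected to remain weak. For compound 3 the estimate in this assay is 80000 nM, ranging from 15000 nM to 300000 nM. The expected step is therefore an at least 1.2-fold lower number from compound 2 to compound 3 (0.09 log units; that floor lies within the scatter), with a real chance that only a limit is reported again.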

Compound 3, half-maximal inhibitory concentration: > 100000 nM
Compound 3: a limit, no number (the forecaster's own chance of this, stated with the estimate: 60%); middle value at least 1.2-fold (0.09 log units) from the limit.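

Compound 3 gives > 100000 nM in this assay, which is a limit and not a number. No step among compound 1, compound 2 and compound 3 can be read, because all three stop at the same point: the limit of > 100000 nM in this assay, at which 3 of the 3 values shown sit.

The compounds shown leave open how the three amide aryl groups on the shared core rank in this assay.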